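The compounds below may be only part of what the source reports. "The series", "measured", "known", "first", "only" and "open" are said of these compounds alone.

Measured in a physicochemical assay for lipophilicity, using the shake flask method, in phosphate buffer, measured as octanol-water partition, with a stated time of 30 min, at pH 7.4; a higher number here means a more lipophilic compound, a lower number a more polar compound:
- compound 1 `Cc1nc(CO)ccc1-c1cnc(NCc2c(F)ccc3c2CCO3)c2cn[nH]c(=O)c12`: 2.4
- compound 2 `O=C1CCCN1c1cnc(NCc2c(F)ccc3c2CCO3)c2cn[nH]c(=O)c12`: 1.8
- compound 3 `Cc1ncccc1-c1cnc(NCc2c(F)ccc3c2CCO3)c2cn[nH]c(=O)c12`: 3

Of these three, compound 3 stands highest, with compound 1 the nearest and compound 2 the furthest below it. Compound 4 `Cc1nc(C(=O)N(C)C)ccc1-c1cnc(NCc2c(F)ccc3c2CCO3)c2cn[nH]c(=O)c12` is built from compound 3 by one change: dimethylcarbamoyl in place of hydrogen on an aromatic carbon. Dimethylcarbamoyl takes the place of hydrogen on an aromatic carbon, next to the ring nitrogen.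

The closest measured comparison is a number 0.60 log units higher from compound 1 to compound 3 (beyond the scatter), a modest step in which hydrogen replaces hydroxymethyl on that same carbon. Read in reverse, it links a group at this carbon with a lower number. The large a number 1.20 log units higher from compound 2 to compound 3 (beyond the scatter) exchanges a different group and bears on the question only loosely. No carbamoyl group has been measured here, so the hydroxymethyl comparison is only a guide.

A modest downward step is therefore expected in this assay. The estimated step is a number 0.50 log units lower from compound 3 to compound 4 (beyond the scatter). Compound 4 is expected at 2.5, with an estimated range of 2.1 to 2.9.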

Compound 4, distribution coefficient: 2.1
Beside the measured number, compound 4's estimate is 0.40 log units above it; low and high end bracket the measured number.
By their numbers in this assay, from the lowest: compounds 2, 4 and 1 (each within the scatter of the next, the first and the last beyond it); then compound 3.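

In this assay, the aromatic carbon next to the ring nitrogen now carries a second group besides hydrogen: dimethylcarbamoyl gives a number 0.90 log units lower from compound 3 to compound 4 (beyond the scatter), so the downward step seen with hydroxymethyl is not confined to that one group. Exchanging one group for the other at this carbon gives a number 0.30 log units lower from compound 1 to compound 4 (within the scatter), which leaves the carbamoyl and hydroxymethyl compounds indistinguishable in this measurement, even though dimethylcarbamoyl enters with 5 heavy atoms and no hydrogen-bond donor. No supporting data are available to explain either step.

From the compounds shown here alone, whether a primary carboxamide, an amine or a carboxylic acid on this carbon would fall in the same range remains open. The compounds shown also leave open whether a longer chain, such as a methoxyethyl group, would stay with these two or move back toward compound 3.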